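Chlorophenyl variant of a benzisoselenazolone-thiadiazole series

This account rests on a few compounds, and the source may have more. Where it says the series, first, only, none or still open, it means among the compounds named here.

Measured so far:
compound 1 `COc1ccc(-c2nnc(-n3[se]c4ccccc4c3=O)s2)cc1`: 5930 nM
compound 2 `Cc1cccc(-c2nnc(-n3[se]c4ccccc4c3=O)s2)c1`: 14800 nM
compound 3 `Cc1ccccc1-c1nnc(-n2[se]c3ccccc3c2=O)s1`: 18600 nM

In a functional assay on A549 cells (Homo sapiens) for antiproliferative activity, read by CCK-8 assay, with a stated time of 48 h (on this read-out lower numbers stand for stronger inhibition and higher numbers for weaker inhibition), compound 3 gives the highest number of the three. Its nearest neighbour is compound 2, with a 1.3-fold higher number from compound 2 to compound 3 (0.10 log units; within the scatter) separating them, a shift too small to call a change. For the measured compounds named here, compound 1 lies furthest away with its value of 5930 nM, a gap that does go beyond the scatter, though no single-point step connects compound 1 and compound 3.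

Compound 4 `O=c1c2ccccc2[se]n1-c1nnc(-c2ccc(Cl)cc2)s1` is not yet measured. The difference from compound 3 is 4-chlorophenyl in place of 2-methylphenyl on an aromatic carbon. Going by the values given here, no measured step covers a change of this kind: the only step in hand, from compound 2 to compound 3, moved a methyl within the ring and stayed within the scatter. The lower number of compound 1 hints that a group placed as in compound 4 may sit below compound 3, but this rests on one compound. Compound 4 is therefore expected to show a 2.1-fold lower number from compound 3 to compound 4 (0.32 log units; beyond the scatter), and its value in this assay is estimated at 9000 nM, within 3500 nM to 23000 nM.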

Compound 4, half-maximal inhibitory concentration: 10400 nM
Compound 4: middle estimate off by 1.2-fold (0.06 log units), on the low side; measured number inside the range.
By their numbers in this assay, from the lowest: compounds 1, 4, 2 and 3 (each within the scatter of the next, the first and the last beyond it).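

In this assay, the position on the aromatic carbon next to the ring nitrogen and the ring sulfur now carries 4-chlorophenyl, and the exchange for either methylphenyl group gives a 1.8-fold lower number from compound 3 to compound 4 (0.25 log units; within the scatter) and a 1.4-fold lower number from compound 2 to compound 4 (0.15 log units; within the scatter), so neither exchange separates the compounds. Chloro in place of methoxy gives a 1.8-fold higher number from compound 1 to compound 4 (0.24 log units; within the scatter), so compound 4 sits within the scatter of all three earlier compounds, although compound 1 and compound 3 are printed beyond it from each other. No supporting data bear on these results.

Going by these compounds, what an amine or a carboxylic acid on this phenyl ring would do in this assay remains open. With 4-chlorophenyl the only chlorinated group shown, the compounds also leave open whether 2-chlorophenyl or 3-chlorophenyl would read any differently.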